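A few compounds are considered here, and "the series" means these few. Any claim that something is new, unique, unknown or untested is made for them only; others in the source may bear on it.

Compound 1, `O=C1CSC(=O)N1C[C@H]1CN(c2ccc(-n3cc(-c4ccccn4)cn3)c(F)c2)C(=O)O1`: in an ADME assay on L02 cells (Homo sapiens) for cytotoxicity, read by MTT assay, with a stated time of 48 h (on this read-out higher numbers stand for weaker inhibition and lower numbers for stronger inhibition), compound 1 gives > 400 ug/mL, which is a limit of the assay rather than a number.
Compound 2, `COC[C@H]1CN(c2ccc(-n3cc(-c4ccccn4)cn3)c(F)c2)C(=O)O1`: in this assay compound 2 gives > 400 ug/mL, again a limit rather than a number.

Compound 2 therefore stands at the limit itself: the limit of > 400 ug/mL in this assay, at which 2 of the 2 values shown sit. Among the measured compounds shown here, the one change within the measured pair, a step that the two limits leave unreadable from compound 1 to compound 2, cannot be read, because both of its values are limits.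

Compound 3, `CONC(=O)[C@H]1CN(c2ccc(-n3cc(-c4ccccn4)cn3)c(F)c2)C(=O)O1`, differs from compound 2 in one place: methoxycarbamoyl in place of methoxymethyl on a saturated ring carbon. For the measured compounds named here, no measured step speaks to this change; the only step available is the unreadable one from compound 1 to compound 2, so it neither supports nor argues against a shift in either direction.

With nothing pointing toward stronger inhibition, compound 3 is expected to stay where compound 2 stands, and the step that the limit leaves unreadable from compound 2 to compound 3 is estimated to be none beyond the scatter. In this assay compound 3 is estimated at 450 ug/mL, with a range from 250 ug/mL to 800 ug/mL, and the assay is expected most likely to report only a limit once more.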

Compound 3, half-maximal inhibitory concentration: > 400 ug/mL
Compound 3: only a limit was reported; the forecaster's own chance of this, stated with the estimate: 80%; the middle value lies beyond the limit too.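

The steps among compound 1, compound 2 and compound 3 cannot be read, as compound 3, like the other two, gives only a limit rather than a number in this assay: the limit of > 400 ug/mL in this assay, at which 3 of the 3 values shown sit.

The compounds shown leave open whether any of these changes of group shifts the result in this assay at all, and by how much.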